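From vinyloxy to formyl on the shared core

The compounds below may be only part of what the source reports. "The series", "measured", "known", "first", "only" and "open" are said of these compounds alone.

compound 1 `C=C(C)c1ccccc1OC(C)C1=NCCN1`: 1580 nM
compound 2 `C=COc1ccccc1OC(C)C1=NCCN1`: 3160 nM

Compound 2 holds the highest of the two numbers in a functional assay on CHO cells for agonist activity at Alpha-2B adrenergic receptor (Homo sapiens); on this read-out lower numbers stand for an effect already at smaller amounts and higher numbers for an effect only at larger amounts of compound; its nearest neighbour is compound 1, and a 2.0-fold higher number from compound 1 to compound 2 (0.30 log units; within the scatter) lies within the scatter. Compound 3 `CC(Oc1ccccc1C=O)C1=NCCN1` differs from compound 2 by formyl in place of vinyloxy on an aromatic carbon. Among the compounds with values here, no measured step involves a formyl group; the only measured step, a 2.0-fold higher number from compound 1 to compound 2 (0.30 log units; within the scatter), exchanged one small group on an aromatic carbon and stayed within the scatter. Compound 3 is therefore expected near 3000 nM in this assay, between 800 nM and 12000 nM. The expected step of a 1.1-fold lower number from compound 2 to compound 3 (0.02 log units; within the scatter) is estimated to stay within the scatter.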

Compound 3, half-maximal effective concentration: 316 nM
Compound 3: middle estimate off by 9.5-fold (0.98 log units), on the high side; the measured number lies below the stated range.
By their numbers in this assay, from the lowest: compound 3; then compounds 1 and 2 (each within the scatter of the next).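

With formyl on this aromatic carbon, the numbers in this assay move beyond the scatter, with a 10-fold lower number from compound 2 to compound 3 (1.00 log units; beyond the scatter) and a 5.0-fold lower number from compound 1 to compound 3 (0.70 log units; beyond the scatter) while the earlier exchange of 1-methylethenyl for vinyloxy stayed within it. This place therefore responds to the group it carries, although vinyloxy and formyl have the same count of hydrogen-bond acceptors and of double bonds outside aromatic rings. Nothing available accounts for the step.

The compounds shown leave open whether the lower number is particular to formyl. A nitrile, a carboxylic acid or an amine on this carbon might behave alike or differently.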